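The compounds below may be only part of what the source reports. "The series", "measured", "known", "first", "only" and "open" are said of these compounds alone.

Measured in a functional assay on MCF7 cells (Homo sapiens) for cytotoxicity, read by MTT assay, with a stated time of 6 days; on this read-out lower numbers stand for an effect already at smaller amounts and higher numbers for an effect only at larger amounts of compound:
- Compound 1 `COC(=O)c1c(-c2ccc(Br)cc2)oc2ccccc2c1=O`: > 25 ug/mL
- Compound 2 `COc1ccc2oc(-c3ccc(O)cc3)c(C(=O)O)c(=O)c2c1`: > 25 ug/mL
- Compound 3 `COc1cc(-c2cc(=O)c3cc(O)ccc3o2)cc(OC)c1OC`: > 25 ug/mL

Each of these three readings is a limit and not a number. Among the compounds with values here, compound 3 therefore has no exact position, and the whole series so far rests on (the limit of > 25 ug/mL in this assay, at which 3 of the 3 values shown sit). Compound 4 `COc1cc(-c2cc(=O)c3cc(O)ccc3o2)cc(OC)c1O[Si](C)(C)C(C)(C)C` differs from compound 3 in one place, on an oxygen on an aromatic ring, where the methyl gives way to a larger group: a group of 7 heavy atoms (6 carbon, 1 silicon; no ring) in place of one carbon atom, on an oxygen on an aromatic ring. Within the data shown here, no measured pair shows what such a change does. Compound 3 offers only its limit of > 25 ug/mL as a starting point, so no step beyond the scatter is expected in this assay. The expected change is a number no higher from compound 3 to compound 4 (the limit leaves the size open). The estimate for compound 4 is 25 ug/mL, with an expected range from 10 ug/mL to 50 ug/mL.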

Compound 4, concentration for half-maximal effect: 2.01 ug/mL
The estimate for compound 4 lay 12-fold (1.09 log units) above the measured number, and the stated range ends above it.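

In this assay, putting the group of 7 heavy atoms (6 carbon, 1 silicon) in place of the methyl, on an oxygen on an aromatic ring, brings an at least 12-fold lower number from compound 3 to compound 4 (1.09 log units; beyond the scatter). Within the data shown here, this single change is thus enough to produce a measurable number on this core, which the earlier compounds did not show. The remaining readings are limits and not numbers: the limit of > 25 ug/mL in this assay, at which 3 of the 4 values shown sit.

As far as these compounds go, whether the silicon matters, or whether a benzyl group or a longer carbon chain on this oxygen would do the same, stays open. One pair also cannot show whether the change would act alike on the other cores.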